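Trading a Sulfur Side Chain for Isopropyl

The source may report more compounds than this note shows. Statements on the series, on what has been measured and on what is new or still open speak of the compounds shown alone.

Compound 3 `CCCCCCCCCCCCCC(=O)N[C@@H](CCSC)C(=O)Nc1ccn([C@H]2O[C@@H](CO)[C@H](O)[C@H]2O)c(=O)n1` has the lowest number of the three measured compounds in a functional assay on HL-60 cells (Homo sapiens) for cytotoxicity, read by MTT assay, with a stated time of 48 h (a higher number here means a weaker inhibitor, a lower number a stronger inhibitor), giving 272 nM. Compound 1 `CCCCCCCCCCCCCC(=O)N[C@@H](CCC(=O)O)C(=O)Nc1ccn([C@H]2O[C@@H](CO)[C@H](O)[C@H]2O)c(=O)n1` gives 502 nM in this assay, a difference from compound 3 that stays within the scatter, while compound 2 `CCCCCCCCCC(=O)N[C@H](C(=O)Nc1ccn([C@H]2O[C@@H](CO)[C@H](O)[C@H]2O)c(=O)n1)C(C)C` gives 2040 nM, a gap that lies beyond it. Compound 4 `CCCCCCCCCCCCCC(=O)N[C@H](C(=O)Nc1ccn([C@H]2O[C@@H](CO)[C@H](O)[C@H]2O)c(=O)n1)C(C)C` carries isopropyl in place of 2-(methylsulfanyl)ethyl on a saturated chain carbon bound to an amide-type nitrogen and a carbonyl carbon. Within the data shown here, the one measured single step, a 1.8-fold lower number from compound 1 to compound 3 (0.27 log units; within the scatter), exchanged a group at the same place and stayed within the scatter, so a swap here need not move the number far. Compound 2 shares the isopropyl of compound 4 but has a shorter fatty chain, and its number is clearly higher. Compound 4 is therefore expected at 600 nM, with a range from 200 nM to 1800 nM. The expected step is a 2.2-fold higher number from compound 3 to compound 4 (0.34 log units; beyond the scatter).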

Compound 4, half-maximal inhibitory concentration in the HL-60 assay: 32300 nM
Compound 4: middle estimate off by 54-fold (1.73 log units), on the low side; the measured number lies above the stated range.
By their numbers in the HL-60 assay, from the lowest: compounds 3 and 1 (each within the scatter of the next); then compound 2; then compound 4.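

Among these compounds, in the HL-60 assay, this position proves far more sensitive than the earlier compounds showed: isopropyl in place of 2-(methylsulfanyl)ethyl gives a 120-fold higher number from compound 3 to compound 4 (2.07 log units; beyond the scatter), and isopropyl in place of 2-carboxyethyl gives a 64-fold higher number from compound 1 to compound 4 (1.81 log units; beyond the scatter). With isopropyl kept, butyl in place of hydrogen on the fatty chain also gives a 16-fold higher number from compound 2 to compound 4 (1.20 log units; beyond the scatter). In a physicochemical assay for lipophilicity (a higher number here means a more lipophilic compound, a lower number a more polar compound), compound 3 gives 0.88 and compound 4 gives 0.9, a gap within the scatter.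

No evidence at hand explains the large rise in the HL-60 assay. As far as these compounds go, how an amine or a benzyl group would read at this place remains open.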